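The source may report more compounds than this note shows. Statements on the series, on what has been measured and on what is new or still open speak of the compounds shown alone.

Going by the values given here, compound 1 `C=CCn1c(=O)/c(=C\c2cc(F)ccc2C)[nH]c(=O)/c1=C\c1ccccc1OC` is the one member of this small set that comes with a number. In a functional assay on MOLT-4 cells (Homo sapiens) for cytotoxicity, read by CCK-8 assay, with a stated time of 72 h (on this read-out lower numbers stand for stronger inhibition and higher numbers for weaker inhibition), compound 1 gives 3800 nM. Compound 2 `COc1ccccc1/C=c1\c(=O)[nH]/c(=C/c2ccccc2Cl)c(=O)n1C` belongs to the same set, but in this assay compound 2 has "not determined" (no result reported), so compound 1 stands alone on the numbers shown, with nothing to rank it against. Compound 3 `C=CCn1c(=O)/c(=C\c2ccccc2OC)[nH]c(=O)/c1=C\c1ccccc1OC` has not yet been tested in this assay. It differs from compound 1 in one place: 2-methoxyphenyl in place of 5-fluoro-2-methylphenyl on a double-bonded chain carbon bound to an aromatic carbon. Both arms of compound 3 thus carry the same 2-methoxyphenyl group. Among the compounds with values here, no pair of measured compounds shows what such a swap does on this read-out, so the size of the step can only be guessed. With no shown step to lean on, the expectation is a change no larger than the usual scatter, in no settled direction. Compound 3 is therefore estimated to give 4000 nM in this assay, with a likely range from 1500 nM to 12000 nM, meaning an expected step of a 1.1-fold higher number from compound 1 to compound 3 (0.02 log units; within the scatter) that stays inside the scatter.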

Compound 3, half-maximal inhibitory concentration: 13100 nM
Compound 3: middle estimate off by 3.3-fold (0.52 log units), on the low side; measured number above the stated range.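

In this assay, the group on a double-bonded chain carbon bound to an aromatic carbon clearly matters: 2-methoxyphenyl in place of 5-fluoro-2-methylphenyl gives a 3.4-fold higher number from compound 1 to compound 3 (0.54 log units; beyond the scatter) and this modest step lies beyond the scatter. The two groups have the same count of 8 heavy atoms and each has one six-membered aromatic ring of carbon only, yet they differ in that one holds fluorine, the other holds oxygen, and only 2-methoxyphenyl counts a hydrogen-bond acceptor, so this position responds even to a swap that leaves the size in heavy atoms unchanged, with compound 1 the stronger inhibitor of this pair. Nothing shown gives a measured reason for the rise in the number.

From the compounds shown here alone, a single step cannot separate the parts of the swap, so it remains open whether the fluorine, the methyl or the methoxy group accounts for the difference between compound 1 and compound 3. Going by these compounds, it is also open how this position would respond to an aromatic ring carrying an amine, a carboxylic acid or a longer chain.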